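Chlorophenyl analogues in the tetrahydrobenzazepinol series

The source may hold more compounds than are shown below. What is called first, only, known or untested is meant among the compounds shown, and "the series" means these compounds.

Compound 1 `O[C@@H]1Cc2ccccc2N[C@H](c2ccccc2)C1` is the parent of the set. In an ADME assay on Vero cells (Chlorocebus sabaeus) for cytotoxicity, read by MTT assay, with a stated time of 72 h (on this read-out higher numbers stand for lower toxicity in this test and lower numbers for higher toxicity in this test), compound 1 gives > 300000 nM, which is a limit of the assay and not a number. Compound 2 `O[C@@H]1Cc2cc(F)ccc2N[C@H](c2ccccc2)C1` carries the change hydrogen in place of fluoro on an aromatic carbon read in reverse on the shared core. In this assay compound 2 gives > 300000 nM, again a limit of the assay rather than a number. The step that the two limits leave unreadable from compound 1 to compound 2 is therefore not readable, as the limit of > 300000 nM in this assay, at which 2 of the 3 values shown sit, notes for both compounds.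

Compound 3 `O[C@@H]1Cc2cc(F)ccc2N[C@H](c2ccc(Cl)cc2)C1` adds to compound 2 the change (chloro in place of hydrogen on an aromatic carbon). In this assay compound 3 gives 194000 nM, a measured number. The step of an at least 1.5-fold lower number from compound 2 to compound 3 (0.18 log units; that floor lies within the scatter) is the only readable one in the set, and its floor lies within the scatter of this assay.

Compound 4 `O[C@@H]1Cc2ccccc2N[C@H](c2ccccc2Cl)C1` is not yet measured and differs from compound 1 by chloro in place of hydrogen on an aromatic carbon. This is the same kind of change as that from compound 2 to compound 3, but not the same: in compound 3 the chloro sits para to a large group, whereas in compound 4 it sits ortho to a large group. The two cores differ by hydrogen in place of fluoro on an aromatic carbon.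

With compound 1 at a limit, only a lower bound on the step is known there, and the comparable step from compound 2 to compound 3 stayed within scatter; compound 4 is therefore expected to lie near the limit, with an expected step of an at least 1.2-fold lower number from compound 1 to compound 4 (0.09 log units; that floor lies within the scatter). The estimated value for compound 4 in this assay is 240000 nM, spanning 110000 nM to 300000 nM.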

Compound 4, half-maximal cytotoxic concentration: > 300000 nM
Compound 4 was reported as a limit (the forecaster's own chance of this, stated with the estimate: 50%); middle value at least 1.2-fold (0.09 log units) away from the limit.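

In this assay compound 4 gives > 300000 nM, a limit of the assay and not a number. Compound 1 also stands at a limit, so no new step can be read between compound 1 and compound 4, and both compounds sit at the same boundary: the limit of > 300000 nM in this assay, at which 3 of the 4 values shown sit.

The compounds shown leave open what size, if any, the step has for chloro ortho to a large group on the core of compound 1.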